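Replacing the Difluorophenyl Amide with a Cyanophenyl Amide

The source may hold more compounds than are shown below. What is called first, only, known or untested is meant among the compounds shown, and "the series" means these compounds.

Of the compounds shown here, two of this set have been measured. Compound 1 `Cc1cccc(C(=O)Nc2cccc(-c3oc4cc(-c5ccc(F)cc5)ccc4c(=O)c3O)c2)c1` carries a 3-methylphenyl on the carbonyl carbon of the amide; in a functional assay on MCF7 cells (Homo sapiens) for antiproliferative activity, read by CCK-8 assay, with a stated time of 72 h (a lower number here means a stronger inhibitor, a higher number a weaker inhibitor), compound 1 gives 7850 nM. Compound 2 `O=C(Nc1cccc(-c2oc3cc(-c4ccc(F)cc4)ccc3c(=O)c2O)c1)c1cc(F)cc(F)c1` differs only in that a 3,5-difluorophenyl takes the place of the 3-methylphenyl, and in this assay compound 2 gives 2490 nM. The change produced a 3.2-fold lower number from compound 1 to compound 2 (0.50 log units; beyond the scatter), so compound 2 stands as the lower of the two numbers seen so far.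

Compound 3 `N#Cc1ccc(C(=O)Nc2cccc(-c3oc4cc(-c5ccc(F)cc5)ccc4c(=O)c3O)c2)cc1` is not yet measured. It differs from compound 2 in one place: 4-cyanophenyl in place of 3,5-difluorophenyl on a carbonyl carbon. Within the data shown here, only the step from compound 1 to compound 2 bears on this change, and it concerns a different pair of groups on the same carbonyl carbon, so there is no direct precedent for the 4-cyanophenyl. The author therefore expects a step of about a 1.4-fold higher number from compound 2 to compound 3 (0.15 log units; within the scatter) in this assay, not beyond the scatter in either direction, and estimates for compound 3 a value of 3500 nM, within a range from 1200 nM to 10000 nM.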

Compound 3, half-maximal inhibitory concentration: 2660 nM
Compound 3: the middle estimate sits 1.3-fold (0.12 log units) above what was measured; measured number inside the range.
By their numbers in this assay, from the lowest: compounds 2 and 3 (each within the scatter of the next); then compound 1.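

In this assay, the step from the 3,5-difluorophenyl to the 4-cyanophenyl on the carbonyl carbon (a 1.1-fold higher number from compound 2 to compound 3 (0.03 log units; within the scatter)) shows that this position accepts an exchange of both fluorines for a single nitrile with no change that can be told from the scatter, so the earlier gain over the 3-methylphenyl is not tied to the 3,5-difluorophenyl alone. The second comparison, a 3.0-fold lower number from compound 1 to compound 3 (0.47 log units; beyond the scatter) and close in size to the step already seen with the 3,5-difluorophenyl, makes compound 1 the weakest of the three, with two differently substituted phenyl rings on the same side of the 3-methylphenyl. Nothing in hand explains why these two groups read alike or why both part from the 3-methylphenyl.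

With only three groups at this one position, the compounds shown leave open whether the 3-methylphenyl is the unusual case or whether an unsubstituted phenyl would read like compound 1 or like compound 2 and compound 3. They also leave open how a pyridine ring, a saturated ring such as cyclohexyl, or a longer alkyl chain on the carbonyl carbon would fare.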